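The compounds below may be only part of what the source reports. "The series", "measured", "known", "first", "only" and "open" are said of these compounds alone.

Of the compounds shown here, three sharing one core have been measured, and a fourth awaits its number. Compound 1 `CCCC1=C(OCC(C)C)C(CCC)(CCC)C(=O)/C(=C(O)\C=C\c2ccccc2)C1=O` in a functional assay on HCT-8 cells (Homo sapiens) for antiproliferative activity, read by sulforhodamine B assay, with a stated time of 3 days (on this read-out lower numbers stand for an effect already at smaller amounts and higher numbers for an effect only at larger amounts of compound), gives 8 uM, which stands second highest among the three measured numbers. Compound 2 `CCCCC1=C(OC)C(CCCC)(CCCC)C(=O)/C(=C(O)\C=C\c2ccccc2)C1=O` in this assay gives 7.8 uM, and compound 3 `COC1=C(CCC(C)C)C(=O)/C(=C(O)/C=C/c2ccccc2)C(=O)C1(CCC(C)C)CCC(C)C` in this assay gives 13 uM; both numbers lie within the scatter of the value of compound 1, so the measured set shows no real separation. Compound 4 `CCCCOC1=C(CCC)C(=O)/C(=C(O)/C=C/c2ccccc2)C(=O)C1(CCC)CCC` has not yet been measured. It differs from compound 1 in one place: propyl in place of isopropyl on a saturated chain carbon bound to an oxygen on an unsaturated carbon. Since every measured pair here sits within the scatter, no step beyond the scatter is expected in this assay from this change; the expected step is no change at the digits printed from compound 1 to compound 4 (within the scatter). Compound 4 is thus estimated at 8 uM, with a range from 4 uM to 16 uM.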

Compound 4, concentration for half-maximal effect: 8.7 uM
Compound 4: the middle estimate sits 1.1-fold (0.04 log units) below what was measured; low and high end bracket the measured number.
By their numbers in this assay, from the lowest: compounds 2, 1, 4 and 3 (each within the scatter of the next).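

In this assay, the first step read at this place, propyl in place of isopropyl on a saturated chain carbon bound to an oxygen on an unsaturated carbon, gives a 1.1-fold higher number from compound 1 to compound 4 (0.04 log units; within the scatter) and so stays within the scatter. For this one pair, then, isobutoxy and butoxy cannot be told apart in this read-out. Nothing at hand explains this result.

From the compounds shown here alone, whether a longer chain such as octyl, or an amine or a carboxylic acid at the end of this chain, would give a step beyond the scatter stays open.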